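Butyl Chain Extension and Antiproliferative Potency in Two Series

The source may hold more compounds than are shown below. What is called first, only, known or untested is meant among the compounds shown, and "the series" means these compounds.

The measured compounds and their values:
compound 1, `CCCCCCCCCCCCCCNC(=O)[C@@H]1CSC(c2ccc(NC(C)=O)cc2)N1`, gives 3600 nM.
compound 2, `CCCCCCCCCCCCCCCCCCNC(=O)[C@@H]1CSC(c2ccc(NC(C)=O)cc2)N1`, reaches only the limit of the assay, > 60000 nM.
compound 3, `CCCCCCCCCCCCNC(=O)[C@@H]1CSC(c2ccc(N)cc2)N1`, gives 4100 nM.

In an ADME assay on cells (Fibroblast, Homo sapiens) for antiproliferative activity, read by sulforhodamine B assay, with a stated time of 48 h (on this read-out lower numbers stand for stronger inhibition and higher numbers for weaker inhibition), compound 1 gives 3600 nM. Compound 2 is reported only as a limit, > 60000 nM, and not as a number. The change between them is butyl in place of hydrogen on a saturated chain carbon, ten or more bonds along the chain from an amide-type nitrogen; it produced an at least 16-fold higher number from compound 1 to compound 2 (1.22 log units; beyond the scatter), a step that runs into (the limit of > 60000 nM in this assay, at which 1 of the 3 values shown sits). Compound 3 sits with compound 1 within the scatter, so no order between them can be read; how the core of compound 3 differs from the core of compound 1 is not broken down here.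

Compound 4, `CCCCCCCCCCCCCCCCNC(=O)[C@@H]1CSC(c2ccc(N)cc2)N1`, is not yet measured. It differs from compound 3 by butyl in place of hydrogen on a saturated chain carbon, ten or more bonds along the chain from an amide-type nitrogen, which is the same change that took compound 1 to compound 2, at the same place on the chain. The earlier pair gave an at least 16-fold higher number from compound 1 to compound 2 (1.22 log units; beyond the scatter). On that strength compound 4 is expected to show a 15-fold higher number from compound 3 to compound 4 (1.17 log units; beyond the scatter), again large and likely carrying the value to the limit. Compound 4 is therefore estimated at 60000 nM, with a range from 20000 nM to 150000 nM. This rests on one measured pair only, so the expectation is held loosely.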

Compound 4, half-maximal inhibitory concentration: 7400 nM
Estimate against measurement, compound 4: 8.1-fold (0.91 log units) above; the whole stated range lies above it.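

In this assay the same butyl change, placed on the core of compound 3, gives a 1.8-fold higher number from compound 3 to compound 4 (0.26 log units; within the scatter) and so leaves compound 4 not separated from compound 3. Set beside the earlier step, the change does not carry over at the same size from one core to the other: the same change on two cores in this assay, an at least 16-fold higher number (1.22 log units; beyond the scatter) from compound 1 to compound 2 and a 1.8-fold higher number (0.26 log units; within the scatter) from compound 3 to compound 4, at least 9.2-fold (0.96 log units) apart, beyond the scatter of two such steps

The gap rests on two pairs only, compound 2 stands at a limit of the assay and so gives the earlier step no exact size, and compound 1 and compound 3 differ in chain length as well as in core, so the data do not show whether the core alone sets the gap.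

Left open is how a chain longer than that of compound 4 would read on the core of compound 3, and whether the value would then climb as steeply as it did on the core of compound 1. Also open, as far as these compounds go, is how a shorter chain would read on either core, and whether a carboxylic acid or a nitrile in place of the amine of compound 3 would alter the size of the butyl step.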